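A few compounds are considered here, and "the series" means these few. Any claim that something is new, unique, unknown or untested is made for them only; others in the source may bear on it.

Three compounds sharing one core carry different aromatic groups on the sulfonyl. Compound 1 `CC1CCN(C2CCN(S(=O)(=O)c3cccnc3)CC2)CC1`, compound 2 `CC1CCN(C2CCN(S(=O)(=O)c3ccc(-c4ccccc4F)cc3)CC2)CC1` and compound 3 `CC1CCN(C2CCN(S(=O)(=O)c3cccnc3F)CC2)CC1` were tested in a functional assay on DLD-1 cells (Homo sapiens) for antiproliferative activity, read by CellTiter-Glo, with a stated time of 72 h; a higher number here means a weaker inhibitor, a lower number a stronger inhibitor. Compound 1 gives 2400 nM in this assay. Compound 3 reaches only a limit of the assay, > 5000 nM. Compound 2 gives 5 nM in this assay, a number far lower than that of compound 1. The difference between the cores of compound 2 and compound 3 is not broken down here.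

From compound 3 to compound 1 the change is hydrogen in place of fluoro on an aromatic carbon, and it gives an at least 2.0-fold lower number from compound 3 to compound 1 (0.31 log units; beyond the scatter). This step is known only as a lower bound because of the limit of > 5000 nM in this assay, at which 1 of the 3 values shown sits.

Compound 4 `CC1CCN(C2CCN(S(=O)(=O)c3ccc(-c4ccccc4)cc3)CC2)CC1` is not yet measured. From compound 2 to compound 4 the change is hydrogen in place of fluoro on an aromatic carbon. This is the same kind of change, though here it sits on a six-membered aromatic ring of carbon only rather than on a ring with one nitrogen, next to the ring nitrogen. Since removing the fluoro helped from compound 3 to compound 1, compound 4 is expected to stay close to compound 2, with a 1.4-fold higher number from compound 2 to compound 4 (0.15 log units; within the scatter), so compound 4 is estimated at 7 nM in this assay.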

Compound 4, half-maximal inhibitory concentration: 258 nM
For compound 4 the middle estimate is 37-fold (1.57 log units) below the measured one; measured number outside the range, above it.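

Replacing the fluoro by hydrogen, which turns the 2-fluorophenyl group into phenyl, gives a 52-fold higher number from compound 2 to compound 4 (1.71 log units; beyond the scatter) in this assay, so on this core the compound with the fluoro is the stronger inhibitor. On the other core the same change went the opposite way, so its effect does not carry over from one core to the other in this series: the same change on two cores in this assay, an at least 2.0-fold lower number (0.31 log units; beyond the scatter) from compound 3 to compound 1 and a 52-fold higher number (1.71 log units; beyond the scatter) from compound 2 to compound 4, at least 100-fold (2.03 log units) apart, beyond the scatter of two such steps These two pairs do not show why the steps differ or what the change would do on a third core, and the earlier step is known only as a bound: the limit of > 5000 nM in this assay, at which 1 of the 4 values shown sits.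

The compounds shown leave open whether the stronger result of compound 2 is specific to fluoro, or whether a chloro, methyl or methoxy group in the same place would match it. They also leave open what an amine or a carboxylic acid at that place would do.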